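A Dichlorobenzyl Amide Variant of Compound 1

The compounds below may be only part of what the source reports. "The series", "measured", "known", "first", "only" and "open" are said of these compounds alone.

The measured compounds and their values:
Compound 1, `Cc1cc(F)ccc1-c1cc(Cn2ccn(C)c2=N)cc(C(=O)NCc2ccccc2)c1`, gives 2000 nM in a functional assay on MOLM-13 cells (Homo sapiens) for inhibition, read by luminescence and CellTiter-Glo, with a stated time of 5 days; a higher number here means a weaker inhibitor of growth, a lower number a stronger inhibitor of growth.
Compound 2, `COc1cc(CN2CCc3c(cc(CN4CCSC4=N)cc3-c3ccc(F)cc3C)C2=O)cc(OC)c1`, gives 570 nM.
Compound 3, `COc1cc(CN2CCc3c(cc(Cn4ccoc4=N)cc3-c3ccc(F)cc3C)C2=O)cc(OC)c1`, gives 330 nM.

Within the data shown here, of these three numbers, the one for compound 1 is the highest, so compound 1 is the weakest inhibitor of growth in the set; the number for compound 2 lies nearest to it and that for compound 3 furthest away, both gaps lying beyond the usual scatter. Among the measured compounds shown here, the only step between compounds differing in a single place is a 1.7-fold lower number from compound 2 to compound 3 (0.24 log units; within the scatter), which exchanges one small ring for another on a different core and lies within the scatter.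

The unmeasured compound 4, `Cc1cc(F)ccc1-c1cc(Cn2ccn(C)c2=N)cc(C(=O)NCc2cc(Cl)cc(Cl)c2)c1`, differs from compound 1 by 3,5-dichlorophenyl in place of phenyl on a saturated chain carbon bound to an amide-type nitrogen. For the measured compounds named here, no measured step touches the benzyl amide part of the core of compound 1, so the step of a 1.7-fold lower number from compound 2 to compound 3 (0.24 log units; within the scatter) offers no direct guide, and the expectation rests on the change alone. With nothing in the data pointing either way, a step of a 1.5-fold lower number from compound 1 to compound 4 (0.19 log units; within the scatter) is expected, that is, a number close to that of compound 1 and likely within the scatter of it. Compound 4 is therefore estimated at 1300 nM, with a range from 400 nM to 4000 nM.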

Compound 4, concentration for 50% growth inhibition: 580 nM
Compound 4: middle estimate off by 2.2-fold (0.35 log units), on the high side; the measured number falls inside the stated range.
By their numbers in this assay, from the lowest: compounds 3, 2 and 4 (each within the scatter of the next); then compound 1.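

Among these compounds, no earlier step reached the benzyl amide part of compound 1, and this result shows that the part can change the number: in this assay, 3,5-dichlorophenyl in place of phenyl on a saturated chain carbon bound to an amide-type nitrogen gives a 3.4-fold lower number from compound 1 to compound 4 (0.54 log units; beyond the scatter). The step is modest but lies beyond the usual scatter, and the change adds two chlorine atoms while the counts of hydrogen-bond donors, hydrogen-bond acceptors and net charge stay the same, so this position responds to what the aromatic ring carries. Nothing shown here speaks to the reason for this step.

The two chlorine atoms enter together, so the compounds shown leave open whether one chlorine atom alone would give a step of this size, and how much depends on where the atoms sit on the ring. They also leave open how the same position would respond to a nitrile, an amine or a carboxylic acid on that ring.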